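Piperidine substituent variation in a fluorophenyl propanamide series

This account rests on a few compounds, and the source may have more. Where it says the series, first, only, none or still open, it means among the compounds named here.

Compound 1 `CC(C(=O)NCc1ccc(C(F)(F)F)nc1N(C)C)c1ccc(NS(C)(=O)=O)c(F)c1` carries a dimethylamino group on the aromatic ring and in a functional assay on CHO-K1 cells for antagonist activity at transient receptor potential cation channel subfamily V member 1 (Homo sapiens), read by FLIPR (on this read-out lower numbers stand for stronger inhibition and higher numbers for weaker inhibition), compound 1 gives 19.1 nM. Compound 2 `CC(C(=O)NCc1ccc(C(F)(F)F)nc1N1CCC(C)(C)CC1)c1ccc(NS(C)(=O)=O)c(F)c1` gives 0.3 nM; the change is a 64-fold lower number from compound 1 to compound 2 (1.80 log units; beyond the scatter). Compound 3 `Cc1ccc(CC2CCN(c3nc(C(F)(F)F)ccc3CNC(=O)C(C)c3ccc(NS(C)(=O)=O)c(F)c3)CC2)cc1` gives 0.2 nM, the lowest of the three numbers, with compound 2 standing closest and within the scatter and compound 1 far beyond it. Among the measured compounds shown here, no single-point step links compound 2 and compound 3; their two values simply show that both six-membered saturated rings with different groups on the ring carbon sit at the low end of the range.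

Compound 4 `CC(C)OC1CCN(c2nc(C(F)(F)F)ccc2CNC(=O)C(C)c2ccc(NS(C)(=O)=O)c(F)c2)CC1` is the next analogue: isopropoxy in place of 4-methylbenzyl on a saturated ring carbon. For the measured compounds named here, none of the measured steps alters this position directly; the only measured step, from compound 1 to compound 2, concerns the exchange of the amino substituent for the whole ring. The closest guidance comes from the values of compound 2 and compound 3, which lie within the scatter of each other despite different groups at the same ring carbon. A step of no more than the usual scatter is therefore expected, with a slight bias toward a higher number. Compound 4 is expected to give 0.5 nM, in the range 0.15 nM to 2 nM. The expected step is a 2.5-fold higher number from compound 3 to compound 4 (0.40 log units; beyond the scatter).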

Compound 4, inhibition constant: 3 nM
Estimate against measurement, compound 4: 6.0-fold (0.78 log units) below; measured number above the stated range.
By their numbers in this assay, from the lowest: compounds 3 and 2 (each within the scatter of the next); then compound 4; then compound 1.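

The position on the saturated ring carbon is not indifferent to its group: compounds 2 and 3 had left that impression, yet this assay shows a 15-fold higher number from compound 3 to compound 4 (1.18 log units; beyond the scatter) when isopropoxy replaces 4-methylbenzyl. The change also separates compound 4 from the other large-ring analogue, with a 10-fold higher number from compound 2 to compound 4 (1.00 log units; beyond the scatter), so having a substituted piperidine in place of dimethylamino is not enough to reach the low end of the range. Some of the gain over the dimethylamino compound survives, as a 6.4-fold lower number from compound 1 to compound 4 (0.80 log units; beyond the scatter) shows, but this is much less than a 64-fold lower number from compound 1 to compound 2 (1.80 log units; beyond the scatter), and the identity of the ring substituent therefore decides a large part of that gain.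

The measurements shown offer no explanation for the higher number of compound 4.

Compound 4 brings in an oxygen, removes the aromatic ring and has fewer heavy atoms in this group, all in a single change, so these contributions cannot be told apart. From the compounds shown here alone, a benzyloxy group on the same ring carbon would keep both the oxygen and the aromatic ring, while a cyclohexylmethyl group would keep a ring without the oxygen or the aromatic character, and the outcome for either remains open.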